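Swapping 2-methoxyphenyl for thiophen-2-yl in compound 1

The source may hold more compounds than are shown below. What is called first, only, known or untested is meant among the compounds shown, and "the series" means these compounds.

Measured so far in a functional assay on HCT-116 cells (Homo sapiens) for inhibition, read by sulforhodamine B assay, with a stated time of 48 h, tested at 50 uM; on this read-out lower numbers stand for less inhibition of growth and higher numbers for more inhibition of growth at the one concentration tested
compound 1 `COc1ccccc1/C=C/C(=O)/C=C/c1ccc(OCc2cn(CCCOc3cc(=O)oc4ccccc34)nn2)c(OC)c1` gives 53%
compound 2 `COc1cc(/C=C/C(=O)/C=C/c2cccs2)ccc1OCc1cn(CCCCOc2cc(=O)oc3ccccc23)nn1` gives 41%

Compound 1 stands highest of the two numbers, and the gap down to compound 2 lies beyond the scatter. Among the measured compounds shown here, no step between measured compounds that differ in one place is available yet. The next compound to read is compound 3 `COc1cc(/C=C/C(=O)/C=C/c2cccs2)ccc1OCc1cn(CCCOc2cc(=O)oc3ccccc23)nn1`, which has thiophen-2-yl in place of 2-methoxyphenyl on a double-bonded chain carbon bound to a double-bonded chain carbon. Compound 2, which also carries thiophen-2-yl, gives 41% and so a small fall in this assay is expected, probably not clearly beyond the scatter. The expected step of a number 8 percentage points lower from compound 1 to compound 3 (within the scatter) is therefore downward and modest. For compound 3 the estimated value is 45% with an expected range from 31% to 59% in this read-out.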

Compound 3, percent growth inhibition at one concentration: 58%
Compound 3: the middle estimate sits 13 percentage points below what was measured, within the range that was stated.
By their numbers in this assay, from the lowest: compound 2; then compounds 1 and 3 (each within the scatter of the next).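

In this assay, among the compounds shown here, thiophen-2-yl in place of 2-methoxyphenyl on a double-bonded chain carbon bound to a double-bonded chain carbon gives the first single-place comparison, a number 5 percentage points higher from compound 1 to compound 3 (within the scatter), so the two groups cannot be told apart here at the one concentration tested. Thiophen-2-yl is carried by compound 2 at 41% and by compound 3 at 58%, so this group alone does not fix the number. Nothing in hand explains the result.

Open, going by these compounds, is how far this place accepts other groups, such as furan-2-yl, unsubstituted phenyl or a phenyl bearing a carboxylic acid. Also open, on these data alone, is whether the same exchange reads alike on a longer chain, where compound 2 would need a partner carrying 2-methoxyphenyl.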